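From isopropyl to 2-methoxyethyl: what exposure to expect

The source may report more compounds than this note shows. Statements on the series, on what has been measured and on what is new or still open speak of the compounds shown alone.

Within the data shown here, in an ADME assay on the whole organism for pharmacokinetics, with Rattus norvegicus as the target, at a dose of 5 mg/kg by the oral route (on this read-out higher numbers stand for higher exposure at the dose given and lower numbers for lower exposure), compound 2 `Cc1nc(-c2nc[nH]n2)ccc1-c1cnc2c(n1)N(C(C)C)C(=O)CN2` gives 7720 ng.h/mL, the higher of the only two numbers available. The other measured compound, compound 1 `Cc1nc(-c2nc[nH]n2)ccc1-c1cnc2c(n1)N([C@H]1CC[C@@H](O)CC1)C(=O)CN2`, gives 28.5 ng.h/mL. Compound 3 `COCCN1C(=O)CNc2ncc(-c3ccc(-c4nc[nH]n4)nc3C)nc21` keeps the core of compound 2 and changes one group: 2-methoxyethyl in place of isopropyl on an amide-type nitrogen in a ring. Among the measured compounds shown here, only one measured step bears on this change, and it involves the same amide-type nitrogen in a ring. With isopropyl in place of 4-hydroxycyclohexyl, it shows a 270-fold higher number from compound 1 to compound 2 (2.43 log units; beyond the scatter), a large step beyond the scatter. Exposure therefore depends strongly on this group, but one step cannot show how 2-methoxyethyl will behave. Like isopropyl, it has no ring, so a moderate fall is expected, well short of that large step: a 3.9-fold lower number from compound 2 to compound 3 (0.59 log units; beyond the scatter). The estimate for compound 3 is 2000 ng.h/mL, with an expected range from 350 ng.h/mL to 9000 ng.h/mL.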

Compound 3, area under the concentration-time curve: 5140 ng.h/mL
Compound 3: the middle estimate sits 2.6-fold (0.41 log units) below what was measured; the measured number falls inside the stated range.
By their numbers in this assay, from the lowest: compound 1; then compounds 3 and 2 (each within the scatter of the next).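

In this assay, putting 2-methoxyethyl in place of isopropyl gives a 1.5-fold lower number from compound 2 to compound 3 (0.18 log units; within the scatter), so the two chains cannot be told apart on this read-out, even though 2-methoxyethyl carries an oxygen and a hydrogen-bond acceptor that isopropyl lacks. The large gap also appears a second time, as a 180-fold higher number from compound 1 to compound 3 (2.26 log units; beyond the scatter), so compound 1, with its 4-hydroxycyclohexyl, now stands far from two different chains that have no ring. Nothing measured here explains why exposure changes so much with the group on this nitrogen.

Going by these compounds, it remains open whether the low number of compound 1 goes with the ring or with its hydroxyl, and a plain cyclohexyl on the same nitrogen would separate the two. On these data alone, how a longer chain, or a chain ending in an amine, would read here is also open.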